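Ethoxy for Fluoro on the Shared Core: Compound 3 Expected

The compounds below may be only part of what the source reports. "The series", "measured", "known", "first", "only" and "open" are said of these compounds alone.

Measured so far:
- Compound 1, `CCOc1ccc2nc(C(=O)Nc3c(F)cc(-c4cccc(F)c4)cc3F)c(C)c(O)c2c1`: 4.56%
- Compound 2, `Cc1c(C(=O)Nc2c(F)cc(-c3cccc(F)c3)cc2F)nc2ccc(F)cc2c1C(=O)O`: 24.5%

In a functional assay on A-375 cells (Homo sapiens) for antiproliferative activity, read by MTT assay, with a stated time of 24 h, tested at 3.7 ug/mL (on this read-out lower numbers stand for a weaker effect and higher numbers for a stronger effect at the one concentration tested), compound 2 gives 24.5%, the higher of the two numbers; compound 1 gives 4.56%, a gap beyond the usual scatter. Compound 2 is therefore the stronger of these two.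

Compound 3, `CCOc1ccc2nc(C(=O)Nc3c(F)cc(-c4cccc(F)c4)cc3F)c(C)c(C(=O)O)c2c1`, is not yet measured. It differs from compound 2 in one place: ethoxy in place of fluoro on an aromatic carbon. Among the compounds with values here, compound 1 also carries an ethoxy group, but it differs from compound 3 elsewhere, so no single step links the two.

Within the data shown here, no measured pair shows this exact change, so the size of the step in this assay cannot be read from earlier numbers. A small shift either way, within or near the scatter, is expected. For compound 3 the estimate is 20%, with a range from 8% to 35%, which means an expected step of a number 4.5 percentage points lower from compound 2 to compound 3 (within the scatter).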

Compound 3, a percentage reported as inhibition, at one concentration (the size of the read-out at that concentration, not a potency): 35.2%
Compound 3: middle estimate off by 15.2 percentage points, on the low side; the whole stated range lies below it.
By their numbers in this assay, from the lowest: compound 1; then compound 2; then compound 3.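

In this assay, the aromatic carbon that carries fluoro in compound 2 also accepts the larger ethoxy group, and the change gives a number 10.7 percentage points higher from compound 2 to compound 3 (beyond the scatter) rather than a loss of effect. Compounds 1 and 2 differ in two places and could not separate these changes, but with ethoxy held fixed, carboxy in place of hydroxy on the other aromatic carbon gives a number 30.6 percentage points higher from compound 1 to compound 3 (beyond the scatter) in this assay, so both single changes can now be read on their own. Nothing measured here explains why either step goes upward.

Only fluoro and ethoxy are shown at the first position, so it remains open whether a longer chain such as butoxy or an amine would raise or lower the number. On these data alone, it is also open whether carboxy in place of hydroxy would give a similar step in compounds carrying fluoro rather than ethoxy.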